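This account rests on a few compounds, and the source may have more. Where it says the series, first, only, none or still open, it means among the compounds named here.

Measured compounds, all in an assay on HEK293 cells for antagonist activity at P2X purinoceptor 7 (Homo sapiens), read by fluorescence, with a stated time of 2 h; a higher number here means a weaker inhibitor, a lower number a stronger inhibitor:

- compound 1 `O=C(c1ccc(Cl)c(C(F)(F)F)c1)N1CCC(n2cncc2-c2ccc(OS(=O)(=O)c3cccc4cnccc34)cc2)CC1` gives 45 nM
- compound 2 `COc1ccc(C(=O)N2CCC(n3cncc3-c3ccc(OS(=O)(=O)c4cccc5cnccc45)cc3)CC2)cc1` gives 77 nM
- compound 3 `CC(C)(O)c1ccc(C(=O)N2CCC(n3cncc3-c3ccc(OS(=O)(=O)c4cccc5cnccc45)cc3)CC2)cc1` gives 109 nM

These three share one core and differ only in the group on the carbonyl carbon of the amide. Compound 2 stands second highest of the three numbers: its nearest neighbour is compound 3, and the step of a 1.4-fold higher number from compound 2 to compound 3 (0.15 log units; within the scatter) is within the scatter, while the step of a 1.7-fold higher number from compound 1 to compound 2 (0.23 log units; within the scatter) is also within the scatter. The largest of the measured steps, a 2.4-fold higher number from compound 1 to compound 3 (0.38 log units; beyond the scatter), is modest.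

Compound 4 `COc1ccc(C(=O)N2CCC(n3cncc3-c3ccc(OS(=O)(=O)c4cccc(C#N)c4)cc3)CC2)cc1` departs from compound 2 at a different place: 3-cyanophenyl in place of isoquinolin-5-yl on a sulfonyl sulfur. Going by the values given here, none of the measured steps touch this part of the molecule; they all concern the amide side, so they give no direct guide to how the sulfonyl-attached group matters. With the amide-side changes all having been small, the working expectation is a modest step, a 1.9-fold higher number from compound 2 to compound 4 (0.29 log units; within the scatter), with much uncertainty in either direction. Compound 4 is therefore estimated at 150 nM, with a range from 40 nM to 600 nM in this assay.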

Compound 4, half-maximal inhibitory concentration: 312 nM
Beside the measured number, compound 4's estimate is 2.1-fold (0.32 log units) below it; the measured number falls inside the stated range.
By their numbers in this assay, from the lowest: compounds 1, 2 and 3 (each within the scatter of the next, the first and the last beyond it); then compound 4.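

In this assay, placing 3-cyanophenyl instead of isoquinolin-5-yl on the sulfonyl sulfur gives a 4.1-fold higher number from compound 2 to compound 4 (0.61 log units; beyond the scatter), so this swap weakens inhibition. This shows that the group on the sulfonyl sulfur can shift the number beyond the scatter, as among the amide-side changes only a 2.4-fold higher number from compound 1 to compound 3 (0.38 log units; beyond the scatter) does. Nothing shown here explains the loss.

This single swap changes two things together: a ring is lost and a nitrile is gained, so the effect of each remains unresolved. As far as these compounds go, a plain phenyl or a naphthalen-1-yl on the sulfonyl sulfur would help separate them, and it also remains open whether the amide groups of compound 1 and compound 3 would give similar steps with 3-cyanophenyl in place.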